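A few compounds are considered here, and "the series" means these few. Any claim that something is new, unique, unknown or untested is made for them only; others in the source may bear on it.

Compound 1 `COc1cc(Cl)cc(-c2nn(-c3cccc(NC(=O)Nc4ccc(Cl)c(C(F)(F)F)c4)c3)cc2-c2ccncc2)c1` is the stronger of the two compounds measured in a functional assay on ACHN cells (Homo sapiens) for inhibition, read by sulforhodamine B assay, with a stated time of 48 h, tested at 100 uM; a lower number here means a stronger effect, a higher number a weaker effect of the compound at the concentration tested. In this assay compound 1 gives -31%, the lowest of the two numbers recorded. The nearest measured neighbour is compound 2 `COc1cc(Cl)cc(-c2nn(-c3cccc(NC(=O)c4cccc(C(F)(F)F)c4)c3)cc2-c2ccncc2)c1`, which in this assay gives 40%. Going by the values given here, the one step between measured compounds that differ in one place is a number 71 percentage points higher from compound 1 to compound 2 (beyond the scatter), and it comes from a 3-(trifluoromethyl)phenyl taking the place of a (4-chloro-3-(trifluoromethyl)phenyl)amino on a carbonyl carbon.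

Compound 3 `O=C(Nc1cccc(-n2cc(-c3ccncc3)c(-c3cc(O)cc(Cl)c3)n2)c1)Nc1ccc(Cl)c(C(F)(F)F)c1` keeps the rest of compound 1 and differs from it only in hydrogen in place of methyl on an oxygen on an aromatic ring. Among the compounds with values here, no measured step touches this part of the molecule: the one step recorded concerns the group on the carbonyl carbon and not the oxygen on the aromatic ring. Nothing in the measured numbers therefore points to a change from this switch, and the expectation is a step of about a number 11 percentage points higher from compound 1 to compound 3 (beyond the scatter), within the scatter. On that basis compound 3 is estimated to give -20% in this assay, expected to fall between -50% and 15%.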

Compound 3, a percentage reported as activity, at one concentration (the size of the read-out at that concentration, not a potency): -25%
Beside the measured number, compound 3's estimate is 5 percentage points above it; the measured number falls inside the stated range.
By their numbers in this assay, from the lowest: compounds 1 and 3 (each within the scatter of the next); then compound 2.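

In this assay, the switch from methoxy to hydroxy on the 3-chloro-5-methoxyphenyl ring gives a number 6 percentage points higher from compound 1 to compound 3 (within the scatter), so at this oxygen the methyl can give way to hydrogen with no readable difference, at the one concentration tested. Going by these compounds alone, this is the first measured look at this part of the molecule, since the earlier step, a number 71 percentage points higher from compound 1 to compound 2 (beyond the scatter), concerned only the group on the carbonyl carbon and said nothing about the oxygen on the aromatic ring. No measurement at hand bears on why methoxy and hydroxy read alike here.

The compounds shown leave open whether this tolerance extends to other groups at the same place, such as an ethoxy, a longer chain ending in an amine, or a carboxylic acid. They also leave open whether hydroxy and methoxy would still read alike with the 3-(trifluoromethyl)phenyl of compound 2 on the carbonyl carbon, where the reading in this assay sits far from that of compound 1.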